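The source may report more compounds than this note shows. Statements on the series, on what has been measured and on what is new or still open speak of the compounds shown alone.

Compound 1 `COC(=O)c1cc(=O)c2c(OC)cc(OC)cc2n1S(=O)(=O)c1ccc(C)cc1`: 6000 nM
Compound 2 `COc1ccc(-c2cc(=O)c3c(OC)cc(OC)cc3n2S(=O)(=O)c2ccc(C)c([N+](=O)[O-])c2)cc1`: > 51700 nM

In a functional assay on KOPN-8 cells (Homo sapiens) for antiproliferative activity, with a stated time of 72 h (on this read-out higher numbers stand for an effect only at larger amounts of compound and lower numbers for an effect already at smaller amounts), compound 1 gives 6000 nM. Compound 2 gives only a limit of the assay, > 51700 nM, and so it stands at the limit of > 51700 nM in this assay, at which 1 of the 2 values shown sits, rather than at a number. Compound 3 `COc1ccc(-c2cc(=O)c3c(OC)cc(OC)cc3n2S(=O)(=O)c2cccc(Br)c2)cc1` differs from compound 2 in one place: 3-bromophenyl in place of 4-methyl-3-nitrophenyl on a sulfonyl sulfur. Among the compounds with values here, no measured pair shows this change, so its size cannot be read from the data. Compound 3 is expected to stay near the limit, with a step of an at least 1.2-fold lower number from compound 2 to compound 3 (0.11 log units; that floor lies within the scatter) that is estimated as no larger than the usual scatter. The value of compound 3 is estimated at 40000 nM, in a range from 8000 nM to 150000 nM.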

Compound 3, half-maximal effective concentration: > 58600 nM
Compound 3: a limit, no number (the forecaster's own chance of this, stated with the estimate: 60%); middle value at least 1.4-fold (0.16 log units) from the limit.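

In this assay compound 2 and compound 3 each give only a limit, not a number, and the step between them cannot be read. The compounds shown leave open whether 3-bromophenyl in place of 4-methyl-3-nitrophenyl changes the effect at all.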